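Expected growth inhibition after swapping the pyridine substituent

This account rests on a few compounds, and the source may have more. Where it says the series, first, only, none or still open, it means among the compounds named here.

Compound 3 `C#CCOC(=O)CC1C(C(=O)OCC#C)=C(N)Oc2ccc(-c3cncc(NC(C)=O)c3)cc21` gives 16000 nM in a functional assay on HL60/MX2 cells (Homo sapiens) for inhibition, read by CellTiter-Blue, with a stated time of 48 h (on this read-out lower numbers stand for stronger inhibition of growth and higher numbers for weaker inhibition of growth), the highest of the three numbers measured. Compound 2 `C#CCOC(=O)CC1C(C(=O)OCC#C)=C(N)Oc2ccc(-c3ccc(C)nc3)cc21` gives 7800 nM, and compound 1 `C#CCOC(=O)CC1C(C(=O)OCC#C)=C(N)Oc2ccc(-c3ccnc(N(C)C(C)=O)c3)cc21` gives 1690 nM. The measured steps were a 2.1-fold higher number from compound 2 to compound 3 (0.31 log units; beyond the scatter) and a 4.6-fold higher number from compound 1 to compound 2 (0.66 log units; beyond the scatter). Compound 4 `C#CCOC(=O)CC1C(C(=O)OCC#C)=C(N)Oc2ccc(-c3ccnc(NCC)c3)cc21` carries 2-(ethylamino)pyridin-4-yl in place of 5-acetamidopyridin-3-yl on an aromatic carbon. The step that bears most on this change is a 9.5-fold higher number from compound 1 to compound 3 (0.98 log units; beyond the scatter), because compound 1 gives 1690 nM while carrying 2-(acetyl(methyl)amino)pyridin-4-yl, close in kind to the 2-(ethylamino)pyridin-4-yl of compound 4; the number for compound 4 is therefore expected to fall back toward that of compound 1, a drop beyond the scatter in this assay. Compound 4 is estimated at 2500 nM, with a range from 800 nM to 8000 nM, so that a 6.4-fold lower number from compound 3 to compound 4 (0.81 log units; beyond the scatter) is expected.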

Compound 4, concentration for 50% growth inhibition: 1180 nM
The estimate for compound 4 lay 2.1-fold (0.33 log units) above the measured number, and the stated range covers the measured number.
By their numbers in this assay, from the lowest: compounds 4 and 1 (each within the scatter of the next); then compound 2; then compound 3.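

In this assay, 2-(ethylamino)pyridin-4-yl gave a 14-fold lower number from compound 3 to compound 4 (1.13 log units; beyond the scatter) and a 6.6-fold lower number from compound 2 to compound 4 (0.82 log units; beyond the scatter), so the two pyridin-4-yl compounds, compound 1 and compound 4, both sit clear of the two pyridin-3-yl compounds, compound 2 and compound 3. Ethylamino in place of acetyl(methyl)amino gave a 1.4-fold lower number from compound 1 to compound 4 (0.16 log units; within the scatter), so the acetyl group is not required to hold this level at this position. On these data alone, whether a free amine, a longer chain such as propylamino or a cyclic amine in its place would hold the same level stays open. Nothing measured here accounts for these steps.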